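The source may hold more compounds than are shown below. What is called first, only, known or untested is meant among the compounds shown, and "the series" means these compounds.

Working notes on the series. Compound 3 `CSCCCn1c(=N)sc2cc(OC(F)(F)F)ccc21` gives 4.2 mg/kg in a functional assay on the whole organism with Rattus norvegicus as the target; a higher number here means that more compound is needed for the effect, a lower number that less compound is needed. Compound 2 `C[S+]([O-])Cn1c(=N)sc2cc(OC(F)(F)F)ccc21` gives 2.3 mg/kg there; a 1.8-fold higher number from compound 2 to compound 3 (0.26 log units; within the scatter). Compound 1 `CN(C)S(=O)(=O)CCn1c(=N)sc2cc(OC(F)(F)F)ccc21` reaches only the limit > 10 mg/kg in this assay (the limit of > 10 mg/kg in this assay, at which 1 of the 3 values shown sits). Against that limit, an at least 4.3-fold lower number from compound 1 to compound 2 (0.63 log units; beyond the scatter) and an at least 2.3-fold lower number from compound 1 to compound 3 (0.37 log units; beyond the scatter). Compound 4 `CC[S+]([O-])CCn1c(=N)sc2cc(OC(F)(F)F)ccc21` differs from compound 3 by a group of 4 heavy atoms (2 carbon, 1 oxygen, 1 sulfur; no ring) in place of a group of 3 heavy atoms (2 carbon, 1 sulfur; no ring), on a saturated chain carbon, two bonds along the chain from an aromatic nitrogen. The most telling comparison is compound 2 against compound 3, which showed no step beyond the scatter; the added oxygen on sulfur in compound 4 mirrors that pair, so for this assay no step beyond the scatter is expected, with at most a slightly lower number, a 1.4-fold lower number from compound 3 to compound 4 (0.15 log units; within the scatter). Compound 4 is estimated at 3 mg/kg, between 1.2 mg/kg and 8 mg/kg.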

Compound 4, dose for half-maximal effect: 1.2 mg/kg
Estimate against measurement, compound 4: 2.5-fold (0.40 log units) above; low and high end bracket the measured number.
By their numbers in this assay, from the lowest: compounds 4, 2 and 3 (each within the scatter of the next, the first and the last beyond it). At a limit, above all of these: compound 1.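

In this assay, on a saturated chain carbon, two bonds along the chain from an aromatic nitrogen, the group with oxygen on sulfur in place of (methylsulfanyl)methyl gives a step beyond the scatter, a 3.5-fold lower number from compound 3 to compound 4 (0.54 log units; beyond the scatter). The two compounds with oxygen on sulfur stay close together, with a 1.9-fold lower number from compound 2 to compound 4 (0.28 log units; within the scatter). The step from the limit of compound 1 is only a bound: an at least 8.3-fold lower number from compound 1 to compound 4 (0.92 log units; beyond the scatter).

The whole group changes from compound 3 to compound 4, so the step cannot be assigned to the oxygen alone. As far as these compounds go, how an ethylsulfonyl group or an amine would fare on this chain remains open.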